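The source may report more compounds than this note shows. Statements on the series, on what has been measured and on what is new or still open speak of the compounds shown alone.

Three compounds share one core and differ only in the group on a saturated chain carbon bound to an aromatic nitrogen: compound 1 `CCC(C)(C)Cn1nc(-c2cccs2)c(O)c(C2=NS(=O)(=O)c3cc(NS(C)(=O)=O)ccc3N2)c1=O`, compound 2 `CCC(C)CCn1nc(-c2cccs2)c(O)c(C2=NS(=O)(=O)c3cc(NS(C)(=O)=O)ccc3N2)c1=O` and compound 3 `CC(C)(C)Cn1nc(-c2cccs2)c(O)c(C2=NS(=O)(=O)c3cc(NS(C)(=O)=O)ccc3N2)c1=O`. All three were tested in an in vitro ADME assay on microsomes from liver (Homo sapiens) for metabolic stability, tested at 5 uM; a higher number here means that the compound lasts longer, a lower number that the compound disappears faster. Compound 1 gives > 1 h, which is a limit of the assay and not a number. Compound 2 gives > 1 h, which is also a limit. Compound 3 gives > 1 h, again a limit, so it has no exact place among the others. The whole set sits at the limit of > 1 h in this assay, at which 3 of the 3 values shown sit.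

The next compound is compound 4 `CS(=O)(=O)Nc1ccc2c(c1)S(=O)(=O)N=C(c1c(O)c(-c3cccs3)nn(CC3(C(F)(F)F)CC3)c1=O)N2`, and the change from compound 3 is 1-(trifluoromethyl)cyclopropyl in place of tert-butyl on a saturated chain carbon bound to an aromatic nitrogen. Within the data shown here, three measured steps bear on this site: a step that the two limits leave unreadable from compound 1 to compound 2, a step that the two limits leave unreadable from compound 1 to compound 3 and a step that the two limits leave unreadable from compound 2 to compound 3. None of them has a readable size, and none of them brings in a ring or fluorine, so they offer no size to carry over to the new group. In this assay no direction can be read, and no clear change is expected. The expected step is a step that the limit leaves unreadable from compound 3 to compound 4, estimated from the shared limit alone. For compound 4 the estimated half-life is 1.5 h, with an expected range from 0.7 h to 3 h.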

Compound 4, half-life: > 1 h
Compound 4 gave a limit, no number; the forecaster's own chance of this, stated with the estimate: 75%; the middle value lies beyond the limit too.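

The steps from compound 1, compound 2 and compound 3 to compound 4 cannot be read, since all four compounds now sit at one limit, which is not a number: the limit of > 1 h in this assay, at which 4 of the 4 values shown sit. Going by these compounds, how long each compound actually lasts, and whether changing the group on the saturated chain carbon alters the half-life at all, remains open.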